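Pyridin-4-yl for thiophen-3-yl: an expected solubility

This account rests on a few compounds, and the source may have more. Where it says the series, first, only, none or still open, it means among the compounds named here.

Three measured compounds share one core and differ only in the aromatic group attached to it. Compound 1 `Cc1cc(NCc2ccccn2)n2ncc(-c3ccc(C#N)cc3)c2n1` carries a 4-cyanophenyl group, compound 2 `Cc1cc(NCc2ccccn2)n2ncc(-c3cccc(F)c3)c2n1` a 3-fluorophenyl group, and compound 3 `Cc1cc(NCc2ccccn2)n2ncc(-c3ccsc3)c2n1` a thiophen-3-yl group. In a physicochemical assay for solubility, read by HPLC, using the shake flask method, measured as kinetic solubility, with a stated time of 2 h, at pH 7.4 (on this read-out higher numbers stand for higher solubility and lower numbers for lower solubility), compound 1 gives < 5000 nM, which is a limit of the assay rather than a number. In this assay compound 2 gives 5000 nM. In this assay compound 3 gives 9000 nM, the only other real number shown. Compound 3 and compound 2 cannot be told apart, since the step of a 1.8-fold higher number from compound 2 to compound 3 (0.26 log units; within the scatter) lies within the scatter. The step of an at least 1.8-fold higher number from compound 1 to compound 3 (0.25 log units; that floor lies within the scatter) is open at its top end because compound 1 sits at the limit (the limit of < 5000 nM in this assay, at which 1 of the 3 values shown sits).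

Compound 4 `Cc1cc(NCc2ccccn2)n2ncc(-c3ccncc3)c2n1` has not been measured. It differs from compound 3 in one place: pyridin-4-yl in place of thiophen-3-yl on an aromatic carbon. Within the data shown here, the steps that bear on this change are the two exchanges at the same place, a 1.8-fold higher number from compound 2 to compound 3 (0.26 log units; within the scatter) and an at least 1.8-fold higher number from compound 1 to compound 3 (0.25 log units; that floor lies within the scatter), and neither clearly exceeds the scatter. For compound 4 a step of a 1.3-fold higher number from compound 3 to compound 4 (0.12 log units; within the scatter) in this assay is therefore expected, nothing beyond the scatter. Compound 4 is estimated at 12000 nM, with a range from 5000 nM to 30000 nM.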

Compound 4, solubility: 161000 nM
Compound 4: middle estimate off by 13-fold (1.13 log units), on the low side; the whole stated range lies below it.
By their numbers in this assay, from the lowest: compounds 2 and 3 (each within the scatter of the next); then compound 4.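

Among these compounds, at this position on the shared core, the choice of aromatic group can matter far more in this assay than the earlier compounds showed, as the only readable step among them stayed within the scatter. Pyridin-4-yl stands clear of all three other groups shown, with the steps of an 18-fold higher number from compound 3 to compound 4 (1.25 log units; beyond the scatter), a 32-fold higher number from compound 2 to compound 4 (1.51 log units; beyond the scatter) and an at least 32-fold higher number from compound 1 to compound 4 (1.50 log units; beyond the scatter), all beyond the scatter, even though thiophen-3-yl and pyridin-4-yl are alike in having one aromatic ring with 1 hetero atom and in their counts of hydrogen-bond donors and acceptors. The step from compound 1 gives only a floor, because compound 1 sits at a limit of the assay rather than at a number: the limit of < 5000 nM in this assay, at which 1 of the 4 values shown sits.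

The compounds shown leave open whether the large step depends on where the nitrogen sits in the ring, which pyridin-3-yl would address, and whether pyrimidin-5-yl, with a second ring nitrogen, or an aminopyridine would go further or fall back. They also do not show whether a similar step would appear on a different core, since all four compounds share this one.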